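Amide nitrogen swap on a dihydrofuran scaffold, from cyclohexyl to benzyl

The source may report more compounds than this note shows. Statements on the series, on what has been measured and on what is new or still open speak of the compounds shown alone.

The three measured compounds share one core and differ only in the group on the amide-type nitrogen. Compound 1 `C=CC1=C(C(=O)Nc2ccccc2OC)C(c2ccc(F)cc2)OC1` carries 2-methoxyphenyl there, and in a functional assay on SW480 cells (Homo sapiens) for cytotoxicity, read by MTT assay, with a stated time of 24 h (a lower number here means a stronger inhibitor, a higher number a weaker inhibitor), compound 1 reaches only the limit of the assay, > 100000 nM. Compound 2 `C=CC1=C(C(=O)Nc2ccc(C)cc2)C(c2ccc(F)cc2)OC1` carries 4-methylphenyl, and in this assay compound 2 likewise gives a limit, > 100000 nM. Compound 3 `C=CC1=C(C(=O)NC2CCCCC2)C(c2ccc(F)cc2)OC1` carries cyclohexyl, and in this assay compound 3 also sits at a limit, > 100000 nM. Because every measured value is a limit, the steps a step that the two limits leave unreadable from compound 1 to compound 2, a step that the two limits leave unreadable from compound 1 to compound 3 and a step that the two limits leave unreadable from compound 2 to compound 3 cannot be sized; all three fall under (the limit of > 100000 nM in this assay, at which 3 of the 3 values shown sit).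

Compound 4 `C=CC1=C(C(=O)NCc2ccccc2)C(c2ccc(F)cc2)OC1` is not yet measured. It differs from compound 3 by benzyl in place of cyclohexyl on an amide-type nitrogen. The two steps that bring cyclohexyl onto this nitrogen, from compound 1 and from compound 2, give no readable size, so nothing in the measured set distinguishes aryl, cycloalkyl or arylmethyl groups at this position. On that basis the step that the limit leaves unreadable from compound 3 to compound 4 is expected to stay within the unreadable region. For compound 4 in this assay the estimate is 150000 nM, with a range from 50000 nM to 500000 nM, and most likely another limit rather than a number.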

Compound 4, half-maximal inhibitory concentration: > 100000 nM
Compound 4 was reported as a limit; the forecaster's own chance of this, stated with the estimate: 85%; the middle value is on the limit's open side.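

In this assay compound 4 also gives only a limit, > 100000 nM. Its steps from compound 1, compound 2 and compound 3 therefore cannot be read, and no size can be given for any of them: the limit of > 100000 nM in this assay, at which 4 of the 4 values shown sit.

The compounds shown leave open whether any group on the amide-type nitrogen of the shared core would give a measurable value in this assay.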